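Anilino variation on the shared core: step to compound 4

The source may hold more compounds than are shown below. What is called first, only, known or untested is meant among the compounds shown, and "the series" means these compounds.

Measured compounds in a functional assay on B16-F10 cells (Mus musculus) for inhibition, read by MTT assay, with a stated time of 72 h; a higher number here means a weaker inhibitor, a lower number a stronger inhibitor:
compound 1 `COc1ccc(Nc2nc(SCc3cn(Cc4ccccc4Cl)nn3)nc(-c3ccccc3)c2C#N)cc1` gives 3990 nM
compound 2 `N#Cc1c(Nc2cccc(C(F)(F)F)c2)nc(SCc2cn(Cc3ccccc3Cl)nn2)nc1-c1ccccc1` gives 3710 nM
compound 3 `N#Cc1c(Nc2cccc([N+](=O)[O-])c2)nc(SCc2cn(Cc3ccccc3Cl)nn2)nc1-c1ccccc1` gives 17200 nM

Compound 3 stands at the highest number of the three in this assay. The steps of a 4.3-fold higher number from compound 1 to compound 3 (0.63 log units; beyond the scatter) and a 4.6-fold higher number from compound 2 to compound 3 (0.67 log units; beyond the scatter) both go beyond the scatter, whereas a 1.1-fold lower number from compound 1 to compound 2 (0.03 log units; within the scatter) lies within it. The three compounds differ only in the aryl group on the nitrogen on an aromatic ring.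

Compound 4 `Cc1ccccc1Nc1nc(SCc2cn(Cc3ccccc3Cl)nn2)nc(-c2ccccc2)c1C#N` is not yet measured. It differs from compound 3 in that (2-methylphenyl in place of 3-nitrophenyl on a nitrogen on an aromatic ring). Within the data shown here, no measured step tests 2-methylphenyl directly. The relevant steps are those to compound 3: both of the other aryl groups, 4-methoxyphenyl in compound 1 and 3-(trifluoromethyl)phenyl in compound 2, give lower numbers than the 3-nitrophenyl of compound 3, and with each other they lie within the scatter. A return toward the level of compound 1 and compound 2 is expected for compound 4, meaning an expected step of a 3.8-fold lower number from compound 3 to compound 4 (0.58 log units; beyond the scatter). Among the measured compounds shown here, with only three compounds bearing on it, the estimate for compound 4 in this assay is 4500 nM, with a range of 1800 nM to 12000 nM.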

Compound 4, half-maximal inhibitory concentration: 2760 nM
Compound 4: middle estimate off by 1.6-fold (0.21 log units), on the high side; low and high end bracket the measured number.
By their numbers in this assay, from the lowest: compounds 4, 2 and 1 (each within the scatter of the next); then compound 3.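

In this assay, replacing 3-nitrophenyl with 2-methylphenyl on the nitrogen on an aromatic ring gives a 6.2-fold lower number from compound 3 to compound 4 (0.79 log units; beyond the scatter), which shows that a group new to this position also lies clear of compound 3. The other two comparisons stay within the scatter, at a 1.3-fold lower number from compound 2 to compound 4 (0.13 log units; within the scatter) and a 1.4-fold lower number from compound 1 to compound 4 (0.16 log units; within the scatter), so 2-methylphenyl, 3-(trifluoromethyl)phenyl and 4-methoxyphenyl form one level across these four compounds, with only compound 3 outside it. No measurement shown here accounts for the separate position of the 3-nitrophenyl group.

With a single nitro compound, the gap cannot yet be assigned to the nitro group itself rather than to this one aryl group as a whole. Also open, on these data alone, is whether an amino group or a carboxylic acid in place of the nitro group would stay at the level of compound 3 or join the other three.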